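The source may hold more compounds than are shown below. What is called first, only, known or untested is meant among the compounds shown, and "the series" means these compounds.

Compound 1, `Cc1[nH]c2ccccc2c1C1Nc2ccccc2CO1`, in an assay on isolated protein for inhibition of Alpha glucosidase (Homo sapiens); on this read-out lower numbers stand for stronger inhibition and higher numbers for weaker inhibition: 11500 nM
Compound 2, `Clc1ccc2c(c1)COC(c1c(-c3ccccc3)[nH]c3ccccc13)N2`, in this assay: 11500 nM
Compound 3, `Cc1ccc2c(c1)COC(c1c(C)[nH]c3ccccc13)N2`, in this assay: 11500 nM

Compound 3 stands level with compounds 1 and 2, and the step of no change at the digits printed from compound 1 to compound 3 (within the scatter) shows that adding a methyl to the outer ring of the core made no difference beyond the scatter. Compound 4, `Cc1ccc2c(c1)COC(c1c(-c3ccccc3)[nH]c3ccccc13)N2`, carries the change (phenyl in place of methyl on an aromatic carbon). Among the measured compounds shown here, no single measured step covers this change directly; compounds 1 and 2, which differ in this and one further place, show the same value. Nothing in the data therefore points to a step beyond the scatter, and compound 4 is expected to sit at about 11500 nM, within 5000 nM to 26000 nM, a step of no change at the digits printed from compound 3 to compound 4 (within the scatter).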

Compound 4, half-maximal inhibitory concentration: 11500 nM
Estimate against measurement, compound 4: no gap at the digits printed, and the stated range covers the measured number.
By their numbers in this assay, from the lowest: compounds 1, 2, 3 and 4 (each within the scatter of the next).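

In this assay, phenyl in place of methyl on the aromatic carbon next to the ring nitrogen gives no change at the digits printed from compound 3 to compound 4 (within the scatter), so with the methyl on the outer ring held fixed, this position takes phenyl with no change beyond the scatter. With phenyl held fixed, methyl in place of chloro on the outer ring gives no change at the digits printed from compound 2 to compound 4 (within the scatter). Nothing available here explains why these values coincide. No group shown moves the value at either place. From the compounds shown here alone, whether an amine or a carboxylic acid next to the ring nitrogen would do so remains open.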